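The compounds below may be only part of what the source reports. "The series", "measured", "known", "first", "only" and "open" are said of these compounds alone.

In an in vitro functional assay on CHO-CREluc cells for antagonist activity at growth hormone secretagogue receptor type 1 (Homo sapiens), read by a luciferase reporter, with a stated time of 4 h (a higher number here means a weaker inhibitor, a lower number a stronger inhibitor), compound 1 `Cc1cc2c(cc1Cl)NC(=O)C2(NC(=O)CN1CCN(C)CC1)c1cccc(Cl)c1` gives 1180 nM, compound 2 `CN1CCCN(CC(=O)NC2(c3ccc(Cl)c(Cl)c3)C(=O)Nc3cc(Cl)cc(Cl)c32)CC1` gives 64 nM and compound 3 `CCN1CCC(CC(=O)NC2(c3ccc(Cl)c(Cl)c3)C(=O)Nc3cc(Cl)cc(Cl)c32)CC1` gives 1 nM.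

Compound 3 stands lowest of the three numbers; compound 2 is nearest to it and compound 1 furthest, both separated from it beyond the scatter. Compound 4 `C=CCN1CCN(CC(=O)NC2(c3ccc(Cl)c(Cl)c3)C(=O)Nc3cc(Cl)cc(Cl)c32)CC1` differs from compound 3 by 4-allylpiperazin-1-yl in place of 1-ethylpiperidin-4-yl on a saturated chain carbon bound to a carbonyl carbon. For the measured compounds named here, the one measured step that bears on this is a 64-fold lower number from compound 2 to compound 3 (1.81 log units; beyond the scatter), which replaced the 4-methyl-1,4-diazepan-1-yl group of compound 2 with the 1-ethylpiperidin-4-yl group of compound 3. Compound 4 moves back toward a ring of the kind seen in compound 2, so a step upward is expected, though the size is uncertain. For compound 4 the estimate is 20 nM, from 3 nM to 150 nM, a step of a 20-fold higher number from compound 3 to compound 4 (1.30 log units; beyond the scatter).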

Compound 4, half-maximal inhibitory concentration: 38 nM
Beside the measured number, compound 4's estimate is 1.9-fold (0.28 log units) below it; low and high end bracket the measured number.
By their numbers in this assay, from the lowest: compound 3; then compounds 4 and 2 (each within the scatter of the next); then compound 1.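

At the saturated chain carbon bound to a carbonyl carbon, the step of a 38-fold higher number from compound 3 to compound 4 (1.58 log units; beyond the scatter) shows that the low number of compound 3 does not carry over to 4-allylpiperazin-1-yl, although a six-membered non-aromatic ring is kept. The step of a 1.7-fold lower number from compound 2 to compound 4 (0.23 log units; within the scatter) leaves 4-allylpiperazin-1-yl and 4-methyl-1,4-diazepan-1-yl unseparated, so 1-ethylpiperidin-4-yl alone stands apart among these three groups. No measurement shown accounts for either step.

The change alters the ring and its alkyl group together, and the two contributions remain unresolved. A 4-ethylpiperazin-1-yl group at this place would separate them.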